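From 2,6-dichlorophenyl to phenyl on compound 3

A few compounds are considered here, and "the series" means these few. Any claim that something is new, unique, unknown or untested is made for them only; others in the source may bear on it.

Three related compounds have numbers in a functional assay on FM3A cells (Mus musculus) for inhibition; a higher number here means a weaker inhibitor, a lower number a stronger inhibitor. Compound 1 (`C/C(=C\COc1c(Cl)cccc1Cl)CC/C=C(\C)C1CC(=O)C(C)(C)O1`) gives 51.2 ug/mL, compound 2 (`C/C(=C\COc1ccccc1)CC/C=C(\C)C1CC(=O)C(C)(C)O1`) gives 59 ug/mL, and compound 3 (`C/C(=C\COc1c(Cl)cccc1Cl)CC/C=C(\C)C1=CC(=O)C(C)(C)O1`) gives 35.3 ug/mL. Compound 3 lies within the usual scatter of both others, so these numbers do not rank the three compounds.

Compound 4 (`C/C(=C\COc1ccccc1)CC/C=C(\C)C1=CC(=O)C(C)(C)O1`) has not yet been measured. It differs from compound 3 in one place: phenyl in place of 2,6-dichlorophenyl on an oxygen on a saturated carbon.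

The same replacement has been measured once, and it gave a 1.2-fold higher number from compound 1 to compound 2 (0.06 log units; within the scatter), a step within the scatter. Within the data shown here, the only other measured step, a 1.5-fold lower number from compound 1 to compound 3 (0.16 log units; within the scatter), concerns a different part of the molecule and also stays within the scatter. It shows that the core of compound 3 gives a number close to that of compound 1, so the replacement may behave similarly on both. A single matching pair is thin evidence, but it points to no step beyond the scatter in this assay. The expected change is a 1.1-fold higher number from compound 3 to compound 4 (0.05 log units; within the scatter). For compound 4 the estimated value is 40 ug/mL, with an expected range of 24 ug/mL to 66 ug/mL.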

Compound 4, half-maximal inhibitory concentration: 44.2 ug/mL
For compound 4 the middle estimate is 1.1-fold (0.04 log units) below the measured one, within the range that was stated.
By their numbers in this assay, from the lowest: compounds 3, 4, 1 and 2 (each within the scatter of the next).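

Phenyl in place of 2,6-dichlorophenyl on the oxygen now has a second reading in this assay, as the replacement gives a 1.3-fold higher number from compound 3 to compound 4 (0.10 log units; within the scatter) and so stays within the scatter on a second core, which the single earlier pair could not show: the same change on two cores in this assay, a 1.2-fold higher number (0.06 log units; within the scatter) from compound 1 to compound 2 and a 1.3-fold higher number (0.10 log units; within the scatter) from compound 3 to compound 4, 1.1-fold (0.04 log units) apart, within the scatter of two such steps.

The other change, the swap of the five-membered group on the double-bonded chain carbon, can now also be read with phenyl in place of 2,6-dichlorophenyl, where it gives a 1.3-fold lower number from compound 2 to compound 4 (0.13 log units; within the scatter) and again stays within the scatter: the same change on two cores in this assay, a 1.5-fold lower number (0.16 log units; within the scatter) from compound 1 to compound 3 and a 1.3-fold lower number (0.13 log units; within the scatter) from compound 2 to compound 4, 1.1-fold (0.04 log units) apart, within the scatter of two such steps.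

Taken together, the four compounds form a closed square of two changes, and no side of that square shows a step beyond the scatter, so in this assay the two chlorines on the phenyl ring make no readable difference on either core.

With every step this small, the compounds show no group at this position that moves the number, and they give no direction in which to push it. On these data alone, what a basic amine, a carboxylic acid or a longer chain in place of the phenyl would do on the oxygen stays open, as does whether the same flat picture would hold in any other assay.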